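Swapping a Saturated Chain for an Unsaturated One

The compounds below may be only part of what the source reports. "The series", "measured", "known", "first", "only" and "open" are said of these compounds alone.

Compound 3 `CCCCCn1c(Cc2cc(OC)c(OC)c(OC)c2)nc2c(N)ncnc21` carries a pentyl chain on an aromatic nitrogen of the shared core. In a functional assay on MCF7 cells (Homo sapiens) for antiproliferative activity (on this read-out lower numbers stand for stronger inhibition and higher numbers for weaker inhibition), compound 3 gives 61700 nM. Compound 1 `CCCCCn1c(Cc2cc(OC)c(OC)c(OC)c2)nc2c(N)nc(F)nc21` gives 36300 nM, and compound 2 `COc1cc(Cc2nc3c(N)ncnc3n2CCOC(C)C)cc(OC)c1OC` gives 38900 nM; both lie within the scatter of compound 3, as the steps of a 1.7-fold higher number from compound 1 to compound 3 (0.23 log units; within the scatter) and a 1.6-fold higher number from compound 2 to compound 3 (0.20 log units; within the scatter) show. Compound 4 `CC/C=C\Cn1c(Cc2cc(OC)c(OC)c(OC)c2)nc2c(N)ncnc21` differs from compound 3 by but-1-en-1-yl in place of butyl on a saturated chain carbon bound to an aromatic nitrogen. Neither measured step repeats this change; the nearer one, a change on the same chain, was a 1.6-fold higher number from compound 2 to compound 3 (0.20 log units; within the scatter), and the fluoro step also stayed within scatter. No step beyond the scatter is therefore expected in this assay. Compound 4 is expected to give about 55000 nM, within a range from 20000 nM to 150000 nM, an estimated step of a 1.1-fold lower number from compound 3 to compound 4 (0.05 log units; within the scatter).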

Compound 4, half-maximal inhibitory concentration: 64600 nM
Compound 4: middle estimate off by 1.2-fold (0.07 log units), on the low side; measured number inside the range.
By their numbers in this assay, from the lowest: compounds 1, 2, 3 and 4 (each within the scatter of the next).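

In this assay, going by these compounds alone, the double bond brought in by but-1-en-1-yl in place of butyl gives a 1.0-fold higher number from compound 3 to compound 4 (0.02 log units; within the scatter), the first direct reading of this change at this position. The step of a 1.7-fold higher number from compound 2 to compound 4 (0.22 log units; within the scatter) also stays within the scatter, so the chains of compound 2, compound 3 and compound 4 cannot be told apart here. No available evidence accounts for this result. Still open, from the compounds shown here alone, is whether a much longer chain in place of pentyl would give a step beyond the scatter. The same question stands for a chain ending in an amine or a carboxylic acid.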